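Swapping a methyl for a methoxy on the aryl arm

A few compounds are considered here, and "the series" means these few. Any claim that something is new, unique, unknown or untested is made for them only; others in the source may bear on it.

Measured compounds:
- compound 1, `Cc1ccc(-c2noc(COc3ccc(CCC(=O)O)cc3)n2)cc1`: 300 nM
- compound 2, `O=C(O)CCc1ccc(OCc2noc(-c3ccccc3)n2)cc1`: 2650 nM

In a functional assay on CHO cells for agonist activity at Free fatty acid receptor 1 (Homo sapiens), read by FLIPR and calcium flux, in the presence of a further agent that is not named here (a lower number here means that less compound is needed, a higher number that more compound is needed for the effect), compound 1 gives 300 nM, the lowest of the two numbers, and compound 2 gives 2650 nM, a gap that lies beyond the usual scatter. The two compounds differ in more than one place, so their numbers alone show that compound 1 needs less material for the same effect, without pointing to any single change as the cause.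

Compound 3, `COc1cccc(-c2noc(COc3ccc(CCC(=O)O)cc3)n2)c1`, has not been measured. It differs from compound 1 at one position only: 3-methoxyphenyl in place of 4-methylphenyl on an aromatic carbon. Both arms keep the same shared core and the same acid-bearing side chain.

For the measured compounds named here, no measured pair shows what this kind of swap does here, so the expectation rests on compound 1 alone. Compound 3 is expected to stay close to compound 1, with a step of a 1.5-fold higher number from compound 1 to compound 3 (0.18 log units; within the scatter) that may fall within the scatter or shift slightly toward a higher number. Compound 3 is therefore estimated at 450 nM, with a likely range from 150 nM to 1400 nM.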

Compound 3, half-maximal effective concentration: 2670 nM
Estimate against measurement, compound 3: 5.9-fold (0.77 log units) below; measured number above the stated range.
By their numbers in this assay, from the lowest: compound 1; then compounds 2 and 3 (each within the scatter of the next).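

In this assay, putting 3-methoxyphenyl in place of 4-methylphenyl gives an 8.9-fold higher number from compound 1 to compound 3 (0.95 log units; beyond the scatter), so the number responds clearly to what sits on this aromatic carbon between two ring nitrogen atoms. The earlier comparison involved compounds that differ in more than one place and tied no effect to any single change, whereas here the shared core and the acid-bearing side chain stay the same and a change in the aryl arm alone moves the number beyond the scatter. Nothing measured here gives a reason for this step.

This one step combines two differences, as the group on the phenyl ring changes from methyl to methoxy and its place on that ring changes too, and the compounds shown cannot separate the two. Going by these compounds, it also remains open whether a phenyl arm carrying a chlorine atom, an amine or a longer chain such as ethoxy would give a number closer to that of compound 1 or to that of compound 3.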